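From Propyl to Phenyl on the Amide Carbonyl

The compounds below may be only part of what the source reports. "The series", "measured", "known", "first", "only" and "open" are said of these compounds alone.

Within the data shown here, only two compounds have been measured so far in a functional assay on SiHa cells (Homo sapiens) for inhibition; a lower number here means a stronger inhibitor, a higher number a weaker inhibitor. Compound 1 (`COc1cc(/C=C/C(=O)c2cccc(NC(=O)c3ccc(Cl)cc3)c2)ccc1O`) gives 2.3 ug/mL, and compound 2 (`CCCC(=O)Nc1cccc(C(=O)/C=C/c2ccc(O)c(OC)c2)c1`) gives 3.94 ug/mL. These two values lie within the scatter of each other, so compound 2 cannot be ranked against compound 1. Among the measured compounds shown here, the single measured step, a 1.7-fold higher number from compound 1 to compound 2 (0.23 log units; within the scatter), puts propyl in place of 4-chlorophenyl on a carbonyl carbon.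

Compound 3 (`COc1cc(/C=C/C(=O)c2cccc(NC(=O)c3ccccc3)c2)ccc1O`) departs from compound 2 at that same carbonyl carbon: phenyl in place of propyl on a carbonyl carbon. This places phenyl in place of propyl, an exchange of a ring for a chain like the measured one, but in the reverse sense. Given a 1.7-fold higher number from compound 1 to compound 2 (0.23 log units; within the scatter), no change beyond the scatter is expected in this assay. The expected step is a 1.3-fold lower number from compound 2 to compound 3 (0.12 log units; within the scatter). For compound 3 the estimated value is 3 ug/mL, with an expected range of 1.5 ug/mL to 6 ug/mL.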

Compound 3, half-maximal inhibitory concentration: 4.57 ug/mL
Beside the measured number, compound 3's estimate is 1.5-fold (0.18 log units) below it, and the stated range covers the measured number.
By their numbers in this assay, from the lowest: compounds 1, 2 and 3 (each within the scatter of the next).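

In this assay, phenyl in place of propyl on the carbonyl carbon gives a 1.2-fold higher number from compound 2 to compound 3 (0.06 log units; within the scatter), so a six-membered aromatic ring and a propyl chain at this position cannot be told apart. Hydrogen in place of chloro on an aromatic carbon gives a 2.0-fold higher number from compound 1 to compound 3 (0.30 log units; within the scatter), so the chloro group has no readable effect here either, and compound 1, compound 2 and compound 3 cannot be ranked. No other evidence bears on these results.

Going by these compounds, whether any group on that carbonyl carbon can move the number beyond the scatter remains open, as a longer chain, an amine-bearing chain or a carboxylic acid on the chain could show. Also open, on these data alone, is whether a fluoro or methoxy group on the aromatic ring would read differently from chloro and hydrogen.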